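Working notes: benzyl in place of acetyl

The source may report more compounds than this note shows. Statements on the series, on what has been measured and on what is new or still open speak of the compounds shown alone.

Measured so far in a functional assay on A549 cells (Homo sapiens) for cytotoxicity (on this read-out higher numbers stand for an effect only at larger amounts of compound and lower numbers for an effect already at smaller amounts), for this series:
- compound 1 `COc1ccc(/C=C/c2cc(OC)c(OCc3ccccc3)c(OC)c2)cc1` gives > 25 uM (a limit of the assay, not a number)
- compound 2 `COc1ccc(/C=C\c2cc(OC)c(OC(C)=O)c(OC)c2)cc1` gives 21.5 uM (a number)

Going by the values given here, compound 2 with 21.5 uM holds the only actual number in this assay so far. Compound 1 is known only through its limit of > 25 uM and that limit gives no ranking.

Compound 3 `COc1ccc(/C=C\c2cc(OC)c(OCc3ccccc3)c(OC)c2)cc1` differs from compound 2 by benzyl in place of acetyl on an oxygen on an aromatic ring. Among the compounds with values here, no measured step shows what this exchange does in this assay so no change beyond the usual scatter is expected, and neither direction is favoured. The expected step of a 1.1-fold lower number from compound 2 to compound 3 (0.03 log units; within the scatter) is therefore small and rests on compound 2 at 21.5 uM alone. The estimate for compound 3 in this assay is 20 uM within an expected range of 7 uM to 50 uM and a report as a limit alone remains possible.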

Compound 3, concentration for half-maximal effect: 1.04 uM
Compound 3: middle estimate off by 19-fold (1.28 log units), on the high side; measured number outside the range, below it.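

In this assay, going by these compounds alone, benzyl in place of acetyl on an oxygen on an aromatic ring is far from a neutral exchange, giving a 21-fold lower number from compound 2 to compound 3 (1.32 log units; beyond the scatter), the first measured step at this position. The configuration of the double bond also matters with benzyl in place, giving an at least 24-fold lower number from compound 1 to compound 3 (1.38 log units; beyond the scatter), a step that rests on a limit and not on a number for compound 1: the limit of > 25 uM in this assay, at which 1 of the 3 values shown sits. The gap between these two compounds can be assigned to the double bond alone, because of this: the fact that compounds 1 and 3 differ only in the configuration as drawn

Still open, on these data alone, is whether the benzyl ring itself carries the lower number, or whether a methyl, a longer alkyl chain or a chain bearing an amine on this oxygen would do the same. Also open, as far as these compounds go, is whether the double bond configuration makes a step of similar size with acetyl on this oxygen.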